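The source may report more compounds than this note shows. Statements on the series, on what has been measured and on what is new or still open speak of the compounds shown alone.

Compound 3 `COc1ccc2nccc(C3CN(C4CCN(Cc5ccc6ccccc6c5)CC4)C(=O)O3)c2c1` gives 1260 nM in an in vitro functional assay on RBL cells for antagonist activity at C-C chemokine receptor type 8 (Homo sapiens), read by FLIPR and calcium flux (on this read-out higher numbers stand for weaker inhibition and lower numbers for stronger inhibition), the second highest of the three numbers shown: compound 1 `COc1ccc2nccc(C3CN(C4CCN(Cc5cc6ccccc6[nH]5)CC4)C(=O)O3)c2c1` gives 25.1 nM and compound 2 `COc1ccc2nccc(C3CN(C4CCN(Cc5cc6ccccc6n5C)CC4)C(=O)O3)c2c1` gives 3160 nM. The change to compound 4 `CCCCCCN1CCC(N2CC(c3ccnc4ccc(OC)cc34)OC2=O)CC1` is pentyl in place of naphthalen-2-yl on a saturated chain carbon bound to an amine nitrogen in a ring. Going by the values given here, no measured step makes this same exchange. Among the compounds with values here, the steps that bear on this position are a 50-fold higher number from compound 1 to compound 3 (1.70 log units; beyond the scatter) and a 2.5-fold lower number from compound 2 to compound 3 (0.40 log units; beyond the scatter), and a 130-fold higher number from compound 1 to compound 2 (2.10 log units; beyond the scatter) shows how strongly this assay responds to what sits on that chain carbon. The removal of both aromatic rings is therefore expected to move the number further upward, by a modest step, a 4.0-fold higher number from compound 3 to compound 4 (0.60 log units; beyond the scatter). Compound 4 is estimated at 5000 nM, with a range from 1000 nM to 30000 nM.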

Compound 4, half-maximal inhibitory concentration: 501 nM
Beside the measured number, compound 4's estimate is 10-fold (1.00 log units) above it, and the stated range ends above it.
By their numbers in this assay, from the lowest: compound 1; then compound 4; then compound 3; then compound 2.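

Replacing naphthalen-2-yl with the ringless pentyl on the saturated chain carbon bound to an amine nitrogen in a ring gives a 2.5-fold lower number from compound 3 to compound 4 (0.40 log units; beyond the scatter) and, against the N-methylated indole, a 6.3-fold lower number from compound 2 to compound 4 (0.80 log units; beyond the scatter), so a flexible-looking name aside, aromatic rings are not needed there for a lower number. Only the 1H-indol-2-yl group goes lower still, with a 20-fold higher number from compound 1 to compound 4 (1.30 log units; beyond the scatter) as the step to pentyl. No evidence here accounts for these differences. Going by these compounds, whether a longer chain or a chain ending in an amine would lower the number further remains open.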